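The compounds below may be only part of what the source reports. "The series", "measured", "known", "first", "only" and "open" are said of these compounds alone.

Measured so far:
compound 1, `C=CCc1ccc(OCc2cn(-c3ccc(C#N)cc3)nn2)c(O)c1`: 35.7%
compound 2, `C#CCOc1ccc(CC=C)cc1O`: 23.7%

In a functional assay on MCF7 cells (Homo sapiens) for inhibition, read by MTT assay, with a stated time of 72 h, tested at 30 uM (on this read-out higher numbers stand for more inhibition of growth at the one concentration tested and lower numbers for less inhibition of growth), compound 1 gives 35.7%, the highest of the two numbers shown. Compound 2 gives 23.7%, a gap beyond the usual scatter. Compound 3, `C=CCc1ccc(OCc2cn(-c3ccccc3CO)nn2)c(O)c1`, is not yet measured and differs from compound 1 in one place: 2-(hydroxymethyl)phenyl in place of 4-cyanophenyl on an aromatic nitrogen. Among the compounds with values here, no pair of measured compounds shows what such an exchange on the aromatic nitrogen does to growth inhibition, so the expectation rests on compound 1 alone. The step of a number 3.7 percentage points lower from compound 1 to compound 3 (within the scatter) is expected to stay within the scatter, in no clear direction. Compound 3 is estimated at 32%, with a range from 18% to 48%.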

Compound 3, percent growth inhibition at one concentration: 34.5%
The estimate for compound 3 lay 2.5 percentage points below the measured number, and the stated range covers the measured number.
By their numbers in this assay, from the lowest: compound 2; then compounds 3 and 1 (each within the scatter of the next).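

In this assay, 2-(hydroxymethyl)phenyl in place of 4-cyanophenyl on the aromatic nitrogen gives a number 1.2 percentage points lower from compound 1 to compound 3 (within the scatter) and so no readable change in growth inhibition. This position therefore takes either group, even though a nitrile leaves and a hydroxymethyl group with a hydrogen-bond donor enters. Nothing at hand explains why the two numbers lie so close.

Both groups are phenyl rings, so a plain butyl chain on this nitrogen remains an open case. So does a phenyl ring carrying an amine or a carboxylic acid.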